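The source may report more compounds than this note shows. Statements on the series, on what has been measured and on what is new or still open speak of the compounds shown alone.

Measured compounds:

Compound 1, `Cc1ccc(-c2nn(-c3ccccc3)cc2C(=O)NOCc2ccccc2)cc1`: 1140 nM
Compound 2, `Cc1ccc(-c2nn(-c3ccccc3)cc2C(=O)NOCc2ccccc2Cl)cc1`: 380 nM
Compound 3, `O=C(NOCc1ccccc1Cl)c1cn(-c2ccccc2)nc1-c1ccc(Cl)cc1`: 15500 nM

All numbers come from a functional assay on A549 cells (Homo sapiens) for antiproliferative activity, read by MTT assay, with a stated time of 48 h, in the presence of a further agent that is not named here; a higher number here means a weaker inhibitor of growth, a lower number a stronger inhibitor of growth. Within this assay the change chloro in place of hydrogen on an aromatic carbon gives a 3.0-fold lower number from compound 1 to compound 2 (0.48 log units; beyond the scatter). The change a 41-fold higher number from compound 2 to compound 3 (1.61 log units; beyond the scatter) is the largest step in the set, and compound 3 stands highest of the three measured numbers. The difference between the core of compound 1 and the core of compound 3 is not broken down here.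

Compound 4, `O=C(NOCc1ccc(Cl)cc1Cl)c1cn(-c2ccccc2)nc1-c1ccc(Cl)cc1`, is not yet measured. It differs from compound 3 by chloro in place of hydrogen on an aromatic carbon. For the measured compounds named here, this is the same kind of change as the one from compound 1 to compound 2, not the same: there the entering chloro sat ortho to a large group, here it sits meta to a chloro group and para to a large group. Because the earlier step was a 3.0-fold lower number from compound 1 to compound 2 (0.48 log units; beyond the scatter), a step of similar modest size is expected, a 1.9-fold lower number from compound 3 to compound 4 (0.29 log units; within the scatter), though the different surroundings leave it uncertain. Compound 4 is estimated at 8000 nM, expected between 3000 nM and 25000 nM.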

Compound 4, concentration for 50% growth inhibition: 13100 nM
Beside the measured number, compound 4's estimate is 1.6-fold (0.21 log units) below it; measured number inside the range.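

In this assay, going from 2-chlorobenzyl to 2,4-dichlorobenzyl gives a 1.2-fold lower number from compound 3 to compound 4 (0.07 log units; within the scatter). Set beside the earlier chloro step, the two cores cannot be told apart: the same change on two cores in this assay, a 3.0-fold lower number (0.48 log units; beyond the scatter) from compound 1 to compound 2 and a 1.2-fold lower number (0.07 log units; within the scatter) from compound 3 to compound 4, 2.5-fold (0.40 log units) apart, within the scatter of two such steps. For the compounds shown here, this gives no sign that the effect of the change depends on the core, but it does not show that the effect carries over unchanged: the evidence is only two pairs, and the entering chloro stands at a different place in each.

Still open, as far as these compounds go, is how a chloro at one and the same place would compare across both cores. Also open, from the compounds shown here alone, is how a methoxy group or an amine would compare with chloro on the benzyl group.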